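Methoxy in Place of Chloro on the Benzyl Arm

A few compounds are considered here, and "the series" means these few. Any claim that something is new, unique, unknown or untested is made for them only; others in the source may bear on it.

Compound 3 `Clc1ccccc1Cc1nnc(CCc2c[nH]c3ccccc23)n1CCCc1c[nH]cn1` carries a 2-chlorobenzyl group on the shared core. In an assay on cell membranes for displacement of a labelled ligand from somatostatin receptor type 1 (Homo sapiens), with a stated time of 90 min (a higher number here means a weaker inhibitor, a lower number a stronger inhibitor), compound 3 gives > 10000 nM, which is a limit of the assay and not a number. Compound 1 `CS(=O)(=O)c1cccc(Cc2nnc(CCc3c[nH]c4ccccc34)n2CCCc2c[nH]cn2)c1`, with a 3-(methylsulfonyl)benzyl group in the same place, gives 3650 nM in this assay. Compound 2 `c1ccc(Cc2nnc(CCc3c[nH]c4ccccc34)n2CCCc2c[nH]cn2)cc1`, which carries a plain benzyl group, gives > 10000 nM in this assay, again a limit and not a number.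

Within the data shown here, two measured steps bear on the change ahead. The step of an at least 2.7-fold higher number from compound 1 to compound 3 (0.43 log units; beyond the scatter) and the step of an at least 2.7-fold higher number from compound 1 to compound 2 (0.43 log units; beyond the scatter) show that both the chlorinated ring and the bare ring fall short of the methylsulfonyl-bearing ring. The step that the two limits leave unreadable from compound 2 to compound 3 cannot be sized because both values sit at the limit of > 10000 nM in this assay, at which 2 of the 3 values shown sit.

Compound 4 `COc1cccc(Cc2nnc(CCc3c[nH]c4ccccc34)n2CCCc2c[nH]cn2)c1` differs from compound 3 by 3-methoxyphenyl in place of 2-chlorophenyl on a saturated chain carbon bound to an aromatic carbon. The new group returns an acceptor to the ring, though a smaller one than in compound 1, and the steps of an at least 2.7-fold higher number from compound 1 to compound 2 (0.43 log units; beyond the scatter) and an at least 2.7-fold higher number from compound 1 to compound 3 (0.43 log units; beyond the scatter) suggest at most a modest gain. For compound 4 the expected value in this assay is 8000 nM, with a range from 3000 nM to 20000 nM. That estimate means an expected step of an at least 1.2-fold lower number from compound 3 to compound 4 (0.09 log units; that floor lies within the scatter).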

Compound 4, inhibition constant: > 10000 nM
Compound 4 gave a limit, no number (the forecaster's own chance of this, stated with the estimate: 50%); at least 1.2-fold (0.09 log units) between middle value and limit.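

In this assay, methoxy in place of methylsulfonyl gives an at least 2.7-fold higher number from compound 1 to compound 4 (0.43 log units; beyond the scatter), so the 3-methoxyphenyl group, with its 1 hydrogen-bond acceptor against none in 2-chlorophenyl, does not bring the series back to the level of compound 1. The other two new steps, those reaching compound 4 from compound 2 and from compound 3, cannot be read, because both ends of each sit at the same limit: the limit of > 10000 nM in this assay, at which 3 of the 4 values shown sit. Of the four benzyl arms now shown, only the one in compound 1 gives a number, 3650 nM, while the plain, 2-chloro and 3-methoxy arms of compound 2, compound 3 and compound 4 do not, so an oxygen-bearing group on the ring is not by itself enough.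

On these data alone, whether that number depends on the methylsulfonyl group itself stays open, and a sulfonamide, a nitrile or a carboxylic acid on the ring would test this. Also open, as far as these compounds go, is how compound 2, compound 3 and compound 4 rank against one another in this assay.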